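One Structural Change, Tried on Two Related Cores

The compounds below may be only part of what the source reports. "The series", "measured", "known", "first", "only" and "open" are said of these compounds alone.

Of the compounds shown here, three have been measured in a functional assay on Bel-7402 cells (Homo sapiens) for antiproliferative activity, read by MTT assay, with a stated time of 72 h; a higher number here means a weaker inhibitor, a lower number a stronger inhibitor. Compound 1 `Cc1cccc(NC2=C/C(=N/NC(N)=S)C(=O)N=C2Nc2cccc(C)c2)c1` gives 2730 nM, compound 2 `NC(=S)N/N=C1/C=C(Nc2ccc(Cl)cc2)C(Nc2ccc(Cl)cc2)=NC1=O` gives 820 nM, and compound 3 `Cc1cccc(NC2=C/C(=N/N=C(\N)SCc3ccccc3)C(=O)N=C2Nc2cccc(C)c2)c1` gives 8720 nM. Compound 2 has the lowest number of the three, with compound 1 nearest to it and compound 3 furthest away. Compound 1 and compound 2 differ in more than one place, and the difference between the two cores is not broken down here.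

Compound 3 arises from compound 1 by a group of 11 heavy atoms (8 carbon, 2 nitrogen, 1 sulfur; one six-membered aromatic ring of carbon only) in place of a group of 4 heavy atoms (1 carbon, 2 nitrogen, 1 sulfur; no ring), on a double-bonded nitrogen. That change produced a 3.2-fold higher number from compound 1 to compound 3 (0.50 log units; beyond the scatter), a modest weakening that lies beyond the usual scatter of repeated measurements.

Compound 4 `N/C(=N\N=C1\C=C(Nc2ccc(Cl)cc2)C(Nc2ccc(Cl)cc2)=NC1=O)SCc1ccccc1` has not yet been measured. It arises from compound 2 by a group of 11 heavy atoms (8 carbon, 2 nitrogen, 1 sulfur; one six-membered aromatic ring of carbon only) in place of a group of 4 heavy atoms (1 carbon, 2 nitrogen, 1 sulfur; no ring), on a double-bonded nitrogen, the same change at the same kind of position, now carried out on the core of compound 2. Only one earlier example of this change exists among these compounds, so the expectation rests on a single comparison and on the assumption that the two cores respond alike.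

In this assay the expected step is a 3.2-fold higher number from compound 2 to compound 4 (0.50 log units; beyond the scatter), because the earlier instance of the same change gave a 3.2-fold higher number from compound 1 to compound 3 (0.50 log units; beyond the scatter). Compound 4 is therefore estimated at about 2600 nM. For compound 4 the expected range runs from 1200 nM to 6000 nM.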

Compound 4, half-maximal inhibitory concentration: 17300 nM
Compound 4: middle estimate off by 6.7-fold (0.82 log units), on the low side; the whole stated range lies below it.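

In both pairs the larger group raises the number, so the direction of the change carries from one core to the other, but its size does not: the same change on two cores in this assay, a 3.2-fold higher number (0.50 log units; beyond the scatter) from compound 1 to compound 3 and a 21-fold higher number (1.32 log units; beyond the scatter) from compound 2 to compound 4, 6.6-fold (0.82 log units) apart, beyond the scatter of two such steps In this assay, the change on the core of compound 2 gives a 21-fold higher number from compound 2 to compound 4 (1.32 log units; beyond the scatter), which means that the larger loss of potency appears on the core that started out with the lowest number of the three. These two pairs do not show which structural difference between the cores sets the size of the step, since the cores differ in more than one place, and two pairs cannot establish a rule for the whole series.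

The compounds shown leave open how a third core would respond, and whether a core carrying chlorine on one aniline ring and methyl on the other would behave like the core of compound 1 or that of compound 2. They also leave open whether a smaller group on the sulfur, such as a methyl or an ethyl chain, would raise the number as much as the group with the six-membered aromatic ring does.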